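Fluorine placement on the benzamide of compound 1

A few compounds are considered here, and "the series" means these few. Any claim that something is new, unique, unknown or untested is made for them only; others in the source may bear on it.

Compound 1 `O=C(Nc1cccc(-c2oc3cc(-c4ccc(F)cc4)ccc3c(=O)c2O)c1)c1ccccc1F` serves as the reference point of this small set. Among the compounds with values here, in a functional assay on HCC1937 cells (Homo sapiens) for antiproliferative activity, read by CCK-8 assay, with a stated time of 72 h (on this read-out higher numbers stand for weaker inhibition and lower numbers for stronger inhibition), compound 1 gives 10800 nM, the highest of the three numbers measured so far; its nearest neighbour is compound 3 and its furthest is compound 2. Compound 2 `COc1ccc(C(=O)Nc2cccc(-c3oc4cc(-c5ccc(F)cc5)ccc4c(=O)c3O)c2)cc1` gives 5490 nM and compound 3 `COc1ccccc1C(=O)Nc1cccc(-c2oc3cc(-c4ccc(F)cc4)ccc3c(=O)c2O)c1` gives 9050 nM. All three sit within the scatter of one another: a 2.0-fold lower number from compound 1 to compound 2 (0.29 log units; within the scatter), a 1.2-fold lower number from compound 1 to compound 3 (0.08 log units; within the scatter) and a 1.6-fold higher number from compound 2 to compound 3 (0.22 log units; within the scatter).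

Compound 4 `O=C(Nc1cccc(-c2oc3cc(-c4ccc(F)cc4)ccc3c(=O)c2O)c1)c1cccc(F)c1` differs from compound 1 in one place: 3-fluorophenyl in place of 2-fluorophenyl on a carbonyl carbon. Both measured steps out of compound 1 also alter the aryl on the carbonyl carbon: a 2.0-fold lower number from compound 1 to compound 2 (0.29 log units; within the scatter) exchanges the whole aryl, and a 1.2-fold lower number from compound 1 to compound 3 (0.08 log units; within the scatter) exchanges the substituent on it, neither leaving the scatter. Within the data shown here, no measured pair tests the bare relocation of a fluorine, so no direction is expected beyond the scatter. The number expected for compound 4 is 9500 nM, between 4500 nM and 20000 nM. That estimate means a 1.1-fold lower number from compound 1 to compound 4 (0.06 log units; within the scatter), expected to stay within the scatter.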

Compound 4, half-maximal inhibitory concentration: 6590 nM
Beside the measured number, compound 4's estimate is 1.4-fold (0.16 log units) above it; low and high end bracket the measured number.
By their numbers in this assay, from the lowest: compounds 2, 4, 3 and 1 (each within the scatter of the next).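

Moving the fluorine, tested directly here for the first time, gives a 1.6-fold lower number from compound 1 to compound 4 (0.21 log units; within the scatter) in this assay, so this relocation on the aryl of the carbonyl carbon does not separate 3-fluorophenyl from 2-fluorophenyl. The two other new steps, a 1.4-fold lower number from compound 3 to compound 4 (0.14 log units; within the scatter) and a 1.2-fold higher number from compound 2 to compound 4 (0.08 log units; within the scatter), also leave 3-fluorophenyl within the scatter of both methoxy-bearing aryls, so all four groups at this place now read alike, with no exception among the compounds shown. No available evidence accounts for these numbers or bears on this change.

Still open, as far as these compounds go, is whether any group on this carbonyl carbon can move the number beyond the scatter, for instance a phenyl ring carrying an amine or a carboxylic acid. From the compounds shown here alone, whether this flat response holds outside this assay is also open.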